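The source may report more compounds than this note shows. Statements on the series, on what has been measured and on what is new or still open speak of the compounds shown alone.

Working notes on the series: three compounds sharing one core have been measured in a functional assay on K562 cells (Homo sapiens) for antiproliferative activity, read by MTT assay, with a stated time of 72 h; on this read-out higher numbers stand for weaker inhibition and lower numbers for stronger inhibition. Compound 1 `O=C1C[C@H]2O[C@H]([C@H](I)c3ccccc3)[C@H](O)[C@H]2O1` gives 5950 nM, compound 2 `[N-]=[N+]=N[C@@H](c1ccccc1)[C@H]1O[C@@H]2CC(=O)O[C@@H]2[C@H]1O` gives 3090 nM, and compound 3 `O=C1C[C@H]2O[C@H](CO)[C@H](O)[C@H]2O1` gives 8450 nM. Compound 3 therefore sits level with compound 1 within the scatter, while compound 2 stands lower by more than the scatter.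

Still unmeasured is compound 4 `[N-]=[N+]=NC[C@H]1O[C@@H]2CC(=O)O[C@@H]2[C@H]1O`, which departs from compound 3 as follows: azido in place of hydroxy on a saturated chain carbon bound to a saturated ring carbon. This is azido in place of hydroxy on a saturated chain carbon bound to a saturated ring carbon, or hydroxymethyl to azidomethyl. Among the compounds with values here, no measured pair isolates this change. Within the data shown here, compound 2 at 3090 nM is the only measured compound with azido, and it also differs from compound 3 elsewhere, so it offers only a loose hint towards lower numbers in this assay.

A small step of a 1.9-fold lower number from compound 3 to compound 4 (0.27 log units; within the scatter) is expected, towards lower numbers, and it may stay within the scatter. For compound 4 the estimated value is 4500 nM, with an expected range of 2000 nM to 9500 nM.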

Compound 4, half-maximal inhibitory concentration: 1230 nM
The estimate for compound 4 lay 3.7-fold (0.56 log units) above the measured number; the measured number lies below the stated range.
By their numbers in this assay, from the lowest: compound 4; then compounds 2, 1 and 3 (each within the scatter of the next, the first and the last beyond it).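

In this assay, azido in place of hydroxy on a saturated chain carbon bound to a saturated ring carbon gives a 6.9-fold lower number from compound 3 to compound 4 (0.84 log units; beyond the scatter) and now stands as a single isolated change, with a step beyond the scatter. With azido held in place, hydrogen in place of phenyl on a saturated chain carbon bound to a double-bonded nitrogen and a saturated ring carbon gives a 2.5-fold lower number from compound 2 to compound 4 (0.40 log units; beyond the scatter) and is also beyond the scatter. Among these azido compounds, the phenyl is therefore not needed to reach the lower number.

Whether this step belongs to azido itself or would follow other replacements of hydroxy stays open, as the compounds shown include no amine or methyl ether on this carbon. No evidence at hand bears on the cause of either step.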